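A few compounds are considered here, and "the series" means these few. Any claim that something is new, unique, unknown or untested is made for them only; others in the source may bear on it.

Measured compounds in a functional assay on SF-268 cells (Homo sapiens) for cytotoxicity, read by sulforhodamine B assay, with a stated time of 48 h; on this read-out lower numbers stand for stronger inhibition of growth and higher numbers for weaker inhibition of growth:
- compound 1 `CC1=C(C(=O)Nc2ccc(Cl)c(Cl)c2)C(c2cccc(Oc3ccccc3)c2)NC(=S)N1`: 6170 nM
- compound 2 `CC1=C(C(=O)Nc2ccc(F)c(Cl)c2)C(c2cccc(Oc3ccccc3)c2)NC(=O)N1`: 8510 nM
- compound 3 `CC1=C(C(=O)Nc2ccc(F)c(Cl)c2)C(c2ccccc2Cl)NC(=S)N1`: 14800 nM

Compound 1 gives the lowest number of the three. Compound 2 lies within the scatter of it, so the two cannot be ordered. Compound 3 stands beyond the scatter, a weaker growth inhibitor than compound 1.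

Compound 4 `CC1=C(C(=O)Nc2ccc(Cl)c(Cl)c2)C(c2cccc(O)c2)NC(=S)N1` is not yet measured. Against compound 1 it differs in one place: hydrogen in place of phenyl on an oxygen on an aromatic ring, read one bond further out as phenoxy to hydroxy. For the measured compounds named here, no measured pair shows this change here, so no step is known for it. A modest move toward weaker growth inhibition is expected, though a result within the scatter would not surprise. For compound 4 the estimate in this assay is 12000 nM, with a range of 4000 nM to 40000 nM. The step of a 1.9-fold higher number from compound 1 to compound 4 (0.29 log units; within the scatter) is the expected size of this move.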

Compound 4, concentration for 50% growth inhibition: 15800 nM
Beside the measured number, compound 4's estimate is 1.3-fold (0.12 log units) below it; low and high end bracket the measured number.
By their numbers in this assay, from the lowest: compounds 1, 2, 3 and 4 (each within the scatter of the next, the first and the last beyond it).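

In this assay, for the compounds shown here, the phenoxy to hydroxy change gives the first single-change step, a 2.6-fold higher number from compound 1 to compound 4 (0.41 log units; beyond the scatter), so the phenyl on this oxygen counts for something, though the step is modest. Growth inhibition is not lost once that phenyl is gone, and a hydrogen on the oxygen is tolerated at this place. Nothing at hand explains the size of this step.

From the compounds shown here alone, it remains open whether a methyl or a benzyl on this oxygen would stay with compound 1 or move with compound 4.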